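The compounds below may be only part of what the source reports. "The series", "measured", "known", "first", "only" and "open" are said of these compounds alone.

Measured so far:
Compound 1 `Brc1cn2ccnc2c(-c2ccc3ncn(C4CCCCC4)c3c2)n1`: 5.58% in a functional assay on RXF 393 cells (Homo sapiens) for inhibition, read by sulforhodamine B assay, with a stated time of 48 h, tested at 10 uM; a lower number here means less inhibition, a higher number more inhibition at the concentration tested (going by the name of the read-out)
Compound 2 `COc1ccc(-c2cn3ccnc3c(-c3ccc4ncn(C5CCCCC5)c4c3)n2)cc1`: -8.48%
Compound 3 `Clc1ccc(-c2cn3ccnc3c(-c3ccc4ncn(C5CCCCC5)c4c3)n2)cc1`: 6.73%

Compound 3 and compound 1 read the same within the scatter, a number 1.2 percentage points higher from compound 1 to compound 3 (within the scatter), while compound 3 stands above compound 2 by a number 15.2 percentage points higher from compound 2 to compound 3 (beyond the scatter), the only gap beyond the scatter in the set.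

Compound 4 `COc1ccccc1-c1cn2ccnc2c(-c2ccc3ncn(C4CCCCC4)c3c2)n1` differs from compound 3 by 2-methoxyphenyl in place of 4-chlorophenyl on an aromatic carbon. Among the compounds with values here, the steps that bear on this are a number 15.2 percentage points higher from compound 2 to compound 3 (beyond the scatter) and a number 14.1 percentage points lower from compound 1 to compound 2 (beyond the scatter), both modest and both showing the methoxyphenyl variant lower than bromo or chlorophenyl. Within the data shown here, the methoxy group now enters as 2-methoxyphenyl rather than 4-methoxyphenyl, so the earlier steps are only a partial guide. A modest drop is expected, a number 8.7 percentage points lower from compound 3 to compound 4 (within the scatter). Compound 4 is estimated at -2%, within -16% to 12%.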

Compound 4, a percentage reported as inhibition, at one concentration (the size of the read-out at that concentration, not a potency): 0.95%
Beside the measured number, compound 4's estimate is 3 percentage points below it; the measured number falls inside the stated range.
By their numbers in this assay, from the lowest: compounds 2, 4, 1 and 3 (each within the scatter of the next, the first and the last beyond it).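

Within this assay, moving the methoxy group to give 2-methoxyphenyl in place of 4-methoxyphenyl gives a number 9.4 percentage points higher from compound 2 to compound 4 (within the scatter), so the two methoxyphenyl placements are not separated here. The 2-methoxyphenyl group also gives a number 5.8 percentage points lower from compound 3 to compound 4 (within the scatter) against 4-chlorophenyl and a number 4.6 percentage points lower from compound 1 to compound 4 (within the scatter) against bromo, so at this carbon a methoxyphenyl group does not always fall beyond the scatter from these groups. No measurement available here explains these readings.

Still open, from the compounds shown here alone, is whether an amine or a carboxylic acid on the phenyl ring at this carbon would move the reading beyond the scatter.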